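The compounds below may be only part of what the source reports. "The series", "measured", "known", "first", "only" and "open" are said of these compounds alone.

Measured compounds:
compound 1 `COc1ccc(/C=C/C=C/C(=O)N2CCCCC2)cc1OC` with 51.9%
compound 2 `O=C(/C=C/C=C/c1ccc(OC2CCCC2)cc1)N1CCCCC1` with 16.1%
compound 3 `O=C(/C=C/C=C/c1cc(O)c(O)c(O)c1)N1CCCCC1` with 82.5%

In an assay for inhibition of Polyunsaturated fatty acid 5-lipoxygenase (Homo sapiens), read by spectrophotometry, tested at 20 uM (a higher number here means more inhibition at the concentration tested (going by the name of the read-out), a lower number less inhibition), compound 2 gives the lowest of the three numbers. Its nearest neighbour is compound 1, whose value lies beyond the scatter above it, and the furthest is compound 3, also beyond the scatter. Compound 4 `CSc1ccc(/C=C/C=C/C(=O)N2CCCCC2)cc1` has not been measured in this assay. It differs from compound 2 by a single change: methylsulfanyl in place of cyclopentyloxy on an aromatic carbon. Going by the values given here, no step between measured compounds matching this change is known, so the direction rests only on the three values shown. A moderate rise from compound 2 is expected, a number 13.9 percentage points higher from compound 2 to compound 4 (beyond the scatter), but the uncertainty is wide. For compound 4 the estimate in this assay is 30%, with a range from 12% to 55%.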

Compound 4, a percentage reported as inhibition, at one concentration (the size of the read-out at that concentration, not a potency): 11.8%
The estimate for compound 4 lay 18.2 percentage points above the measured number; the measured number lies below the stated range.
By their numbers in this assay, from the lowest: compounds 4 and 2 (each within the scatter of the next); then compound 1; then compound 3.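

In this assay, methylsulfanyl in place of cyclopentyloxy on an aromatic carbon para to a large group gives a number 4.3 percentage points lower from compound 2 to compound 4 (within the scatter). Removing the five-membered ring and the oxygen from this position therefore does not separate the two compounds, and both sit apart from the other compounds' numbers. Nothing available explains this outcome.

Going by these compounds, whether an amine or a carboxylic acid on this aromatic carbon would give a different number stays open. So does whether this change would read the same with a morpholine amide in place of the piperidine amide.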